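Swapping a sulfonamide tail on a shared core

The source may report more compounds than this note shows. Statements on the series, on what has been measured and on what is new or still open speak of the compounds shown alone.

Measured so far:
- compound 1 `CCCS(=O)(=O)NCCCOc1nc(C2CC2)nc(NS(=O)(=O)c2ccc(C(C)C)cn2)c1Oc1ccccc1OC`: 245 nM
- compound 2 `CCS(=O)(=O)NCCCOc1nc(C2CC2)nc(NS(=O)(=O)c2ccc(C(C)(C)C)cc2)c1Oc1ccccc1OC`: 302 nM
- compound 3 `CCCS(=O)(=O)NCCOc1nc(C2CC2)nc(NS(=O)(=O)c2ccc(C(C)C)cn2)c1Oc1ccccc1OC`: 288 nM

All three were tested in a functional assay for inhibition of Endothelin-1 receptor (Rattus norvegicus); a lower number here means tighter binding, a higher number weaker binding. Compound 3 sits second highest of the three numbers, but its nearest neighbour, compound 2, and its furthest, compound 1, both lie within the scatter of it, so the three compounds cannot be told apart on these values.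

The unmeasured compound 4 `COc1ccccc1Oc1c(NS(=O)(=O)c2ccc(C(C)C)cn2)nc(C2CC2)nc1OCCCNS(=O)(=O)c1cccs1` is reached from compound 3 by one change: (((thiophen-2-yl)sulfonyl)amino)methyl in place of (propylsulfonyl)amino on a saturated chain carbon, two bonds along the chain from an oxygen on an aromatic ring.

Among the compounds with values here, only one measured step touches this change. It goes a 1.2-fold higher number from compound 1 to compound 3 (0.07 log units; within the scatter), and it concerns the chain part of the change alone: the same lengthening of the chain, taken in reverse, is part of the move from compound 3 to compound 4. Lengthening or shortening that chain made no difference beyond the scatter. Within the data shown here, the other part of the change, the thiophene ring entering in place of the propyl chain on the sulfonyl group, has no counterpart among the measured compounds, so it adds uncertainty but no known direction.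

The step is therefore expected to be a 1.1-fold lower number from compound 3 to compound 4 (0.04 log units; within the scatter), nothing beyond the scatter. Compound 4 is estimated at 260 nM, with a range from 80 nM to 850 nM.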

Compound 4, dissociation constant: 120 nM
Compound 4: middle estimate off by 2.2-fold (0.34 log units), on the high side; the measured number falls inside the stated range.
By their numbers in this assay, from the lowest: compound 4; then compounds 1, 3 and 2 (each within the scatter of the next).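

Within the data shown here, the sulfonyl group's substituent is the first thing to move the number beyond the scatter. In this assay, thiophen-2-yl in place of propyl on the sulfonyl sulfur, with the chain to the core left unchanged, gives a 2.0-fold lower number from compound 1 to compound 4 (0.31 log units; beyond the scatter), which means tighter binding. The full change also alters the chain and gives a 2.4-fold lower number from compound 3 to compound 4 (0.38 log units; beyond the scatter), while the chain change alone, seen in a 1.2-fold higher number from compound 1 to compound 3 (0.07 log units; within the scatter), stays within the scatter, so the shift is tied to the thiophene ring and not to chain length; nothing available explains why the ring has this effect.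

A single ring-bearing compound cannot show whether the gain is particular to thiophene or would also appear with a furan ring or a longer chain such as butyl on the sulfonyl sulfur. It also remains open whether the thiophene ring would give a similar step on the shorter chain, as a 2-(((thiophen-2-yl)sulfonyl)amino)ethyl group, since the only chain comparison shown involves the propylsulfonyl compounds.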